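Trifluoromethylphenyl to Fluoro-Methoxyphenyl: An Expected Cytotoxicity Shift

The source may hold more compounds than are shown below. What is called first, only, known or untested is meant among the compounds shown, and "the series" means these compounds.

Compound 1 `C#CCOc1cccc(/C=C/C(=O)Nc2cc(C(=O)c3cc(OC)c(OC)c(OC)c3)ccc2OC)c1`: 14000 nM
Compound 2 `COc1ccc(C(=O)c2cc(OC)c(OC)c(OC)c2)cc1NC(=O)/C=C/c1ccc(C(F)(F)F)cc1`: 90 nM

In a functional assay on HeLa cells (Homo sapiens) for cytotoxicity, read by MTT assay, with a stated time of 72 h (on this read-out lower numbers stand for stronger inhibition and higher numbers for weaker inhibition), compound 2 gives the lowest of the two numbers measured; its nearest neighbour, compound 1, sits a 160-fold lower number from compound 1 to compound 2 (2.19 log units; beyond the scatter) away, a gap far beyond the scatter. Compound 3 `COc1cc(/C=C/C(=O)Nc2cc(C(=O)c3cc(OC)c(OC)c(OC)c3)ccc2OC)ccc1F` is not yet measured. It differs from compound 2 by 4-fluoro-3-methoxyphenyl in place of 4-(trifluoromethyl)phenyl on a double-bonded chain carbon bound to a double-bonded chain carbon. For the measured compounds named here, the only measured step, the one from compound 1 to compound 2 with a 160-fold lower number from compound 1 to compound 2 (2.19 log units; beyond the scatter), shows that exchanging the aryl on this chain carbon can move the number a great deal; yet it does not tell how a 4-fluoro-3-methoxyphenyl compares with a 4-(trifluoromethyl)phenyl, since no measured compound carries that group. The step for compound 3 is therefore expected to be smaller than that measured one and most likely toward a higher number, with wide uncertainty. Compound 3 is estimated at 900 nM, with a range from 150 nM to 6000 nM, which means an expected step of a 10-fold higher number from compound 2 to compound 3 (1.00 log units; beyond the scatter).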

Compound 3, half-maximal inhibitory concentration: 13600 nM
Compound 3: middle estimate off by 15-fold (1.18 log units), on the low side; measured number outside the range, above it.
By their numbers in this assay, from the lowest: compound 2; then compounds 3 and 1 (each within the scatter of the next).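

The step of a 150-fold higher number from compound 2 to compound 3 (2.18 log units; beyond the scatter) in this assay shows that the low number of compound 2 does not come with just any fluorine-bearing aryl on this chain carbon, since 4-fluoro-3-methoxyphenyl loses nearly all of it. The step of a 1.0-fold lower number from compound 1 to compound 3 (0.01 log units; within the scatter) stays within the scatter, so 4-fluoro-3-methoxyphenyl and 3-(propargyloxy)phenyl cannot be told apart here. Among these three compounds, 4-(trifluoromethyl)phenyl alone gives a low number, and compounds 1 and 3 both go without it.

On these data alone, the exchange in compound 3 alters the trifluoromethyl and the methoxy together, so it remains open whether a 4-fluorophenyl, a 4-chlorophenyl or a 3-(trifluoromethyl)phenyl would keep the low number of compound 2. No measurement at hand bears on why these numbers differ.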